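This account rests on a few compounds, and the source may have more. Where it says the series, first, only, none or still open, it means among the compounds named here.

Measured so far in a physicochemical assay for lipophilicity, at pH 7.4; a higher number here means a more lipophilic compound, a lower number a more polar compound:
- compound 1 `CC(C)CN(c1ccc(C#N)cc1)S(=O)(=O)c1ccc2c(c1)C(O)CC(C1CCOCC1)O2`: 3.07
- compound 2 `CC(C)CN(c1cccc(F)c1)S(=O)(=O)c1ccc2c(c1)C(O)CC(C1CCOCC1)O2`: 3.39

Of the two, compound 2 holds the higher number at 3.39. Among the compounds with values here, the only measured step, a number 0.32 log units higher from compound 1 to compound 2 (beyond the scatter), is modest and lies beyond the scatter. It replaced 4-cyanophenyl with 3-fluorophenyl on a sulfonamide nitrogen.

The next compound, compound 3 `CC(C)CN(c1ccc(F)cc1F)S(=O)(=O)c1ccc2c(c1)C(O)CC(C1CCOCC1)O2`, keeps the shared core and carries 2,4-difluorophenyl in place of 3-fluorophenyl at that same place: 2,4-difluorophenyl in place of 3-fluorophenyl on a sulfonamide nitrogen.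

Within the data shown here, the measured step bears on this change only indirectly, since a nitrile-bearing group left in that step and no measured pair yet compares one fluorinated phenyl group with another. The present exchange is the narrower of the two, so a step smaller than a number 0.32 log units higher from compound 1 to compound 2 (beyond the scatter) is expected, upward if it shows at all. The expected change is a number 0.08 log units higher from compound 2 to compound 3 (within the scatter), which is not expected to lie beyond the scatter. For compound 3 the estimated value is 3.47, with an expected range of 3.17 to 3.77.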

Compound 3, distribution coefficient: 3.53
Beside the measured number, compound 3's estimate is 0.06 log units below it; the measured number falls inside the stated range.
By their numbers in this assay, from the lowest: compound 1; then compounds 2 and 3 (each within the scatter of the next).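

In this assay, within the data shown here, the step of a number 0.14 log units higher from compound 2 to compound 3 (within the scatter) is the first direct comparison of one fluorinated phenyl group with another on the sulfonamide nitrogen, and it does not separate 2,4-difluorophenyl from 3-fluorophenyl at this place, even with a second fluorine on the ring. The exchange of 4-cyanophenyl for 2,4-difluorophenyl gives a number 0.46 log units higher from compound 1 to compound 3 (beyond the scatter) and lies beyond the scatter, as does the earlier step of a number 0.32 log units higher from compound 1 to compound 2 (beyond the scatter) to 3-fluorophenyl. Among these three compounds, the clear division at this place therefore lies between compound 1 and the two fluorinated compounds, while no measurement shown here accounts for any of these steps.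

On these data alone, it remains open whether an unsubstituted phenyl, a pyridine ring or a methoxyphenyl group on the sulfonamide nitrogen would fall with the fluorinated compounds or with compound 1. A phenyl group carrying an amine or a carboxylic acid would also test this position over a wider range in this assay and show how far the division seen with these three compounds extends.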